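The source may report more compounds than this note shows. Statements on the series, on what has been measured and on what is new or still open speak of the compounds shown alone.

Compound 1 `O=C(NCCCCc1ccccc1)c1cccc(C2SCC(=O)N2c2cccc(F)c2)c1` — 32.4 nM
Compound 2 `O=C(NCCCCn1cccn1)c1cccc(C2SCC(=O)N2c2ccncc2)c1` — > 1000 nM

Among the measured compounds shown here, in a functional assay on HOS-TE85 cells (Homo sapiens) for inhibition, read by CCK-8 assay, with a stated time of 72 h (a higher number here means a weaker inhibitor, a lower number a stronger inhibitor), compound 1 gives 32.4 nM, the only outright number among the values shown. For compound 2 the result is a limit of the assay, > 1000 nM (the limit of > 1000 nM in this assay, at which 1 of the 2 values shown sits). Compound 3 `O=C(NCCCCc1ccccc1)c1cccc(C2SCC(=O)N2c2ccc(C3CC3)cc2)c1` differs from compound 1 in one place: 4-cyclopropylphenyl in place of 3-fluorophenyl on an amide-type nitrogen in a ring. For the measured compounds named here, no step between measured compounds is available to judge this change, so the step of a 1.2-fold higher number from compound 1 to compound 3 (0.09 log units; within the scatter) is expected to be small, within the usual scatter, in either direction. Compound 3 is estimated at 40 nM, with a range of 10 nM to 160 nM.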

Compound 3, half-maximal inhibitory concentration in the HOS-TE85 assay: 217 nM
Beside the measured number, compound 3's estimate is 5.4-fold (0.73 log units) below it, outside the stated range (above it).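

In the HOS-TE85 assay, the group on this amide-type nitrogen in a ring clearly matters: 4-cyclopropylphenyl in place of 3-fluorophenyl gives a 6.7-fold higher number from compound 1 to compound 3 (0.83 log units; beyond the scatter), a weaker inhibitor. In a physicochemical assay for solubility, read by turbidimetry, measured as kinetic solubility, at pH 6.8 (on this read-out higher numbers stand for higher solubility and lower numbers for lower solubility), compound 1 gives 10000 nM and compound 3 gives 2000 nM, so compound 3 is behind on both read-outs.

A single step cannot separate the arrival of the cyclopropyl group from the loss of the fluorine or the different place of the substituent on the phenyl ring. On these data alone, how a phenyl ring carrying an amine or a carboxylic acid would behave here remains open.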